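Swapping a Branched Chain for a Ring

A few compounds are considered here, and "the series" means these few. Any claim that something is new, unique, unknown or untested is made for them only; others in the source may bear on it.

Measured so far:
compound 1 `CCCCOc1nc(C(C)(C)C)ccc1CNC(=O)C(C)c1ccc(NS(C)(=O)=O)c(F)c1`: 0.9 nM
compound 2 `CC(C)CCOc1nc(C(C)(C)C)ccc1CNC(=O)C(C)c1ccc(NS(C)(=O)=O)c(F)c1`: 0.8 nM

In an assay on cells for antagonist activity at transient receptor potential cation channel subfamily V member 1 (Homo sapiens), read by FLIPR and calcium flux, with a stated time of 6 min (on this read-out higher numbers stand for weaker inhibition and lower numbers for stronger inhibition), compound 2 gives 0.8 nM, and compound 1 gives 0.9 nM; the two lie within the usual scatter of each other, so neither can be called stronger. Compound 3 `CC(C(=O)NCc1ccc(C(C)(C)C)nc1OC1CCCCC1)c1ccc(NS(C)(=O)=O)c(F)c1` differs from compound 2 in one place: cyclohexyl in place of isopentyl on an oxygen on an aromatic ring. For the measured compounds named here, the only measured step, a 1.1-fold lower number from compound 1 to compound 2 (0.05 log units; within the scatter), lengthened the same chain and changed nothing beyond the scatter. Going by the values given here, no measured pair shows a chain turning into a ring, so the expectation rests on that single step. Compound 3 is therefore expected to stay close, a 1.5-fold higher number from compound 2 to compound 3 (0.18 log units; within the scatter), at about 1.2 nM, somewhere between 0.4 nM and 4 nM.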

Compound 3, inhibition constant: 2.5 nM
For compound 3 the middle estimate is 2.1-fold (0.32 log units) below the measured one; the measured number falls inside the stated range.
By their numbers in this assay, from the lowest: compounds 2 and 1 (each within the scatter of the next); then compound 3.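

On an oxygen on an aromatic ring, this assay does distinguish between these groups: cyclohexyl in place of isopentyl gives a 3.1-fold higher number from compound 2 to compound 3 (0.49 log units; beyond the scatter), and cyclohexyl in place of butyl gives a 2.8-fold higher number from compound 1 to compound 3 (0.44 log units; beyond the scatter). Both steps are modest but beyond the scatter, whereas the step between the two open chains stayed within it. No measurement here explains this difference. Still open, on these data alone, is whether the change follows from the ring itself or is specific to cyclohexyl. A cyclopentyl or phenyl group at this oxygen would test that.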